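This account rests on a few compounds, and the source may have more. Where it says the series, first, only, none or still open, it means among the compounds named here.

Compound 1 `COc1ccc2occ(CSC(=S)N(C(C)C)C(C)C)c(=O)c2c1` and compound 3 `COc1ccc2occ(CSC(=S)N3CCCC3)c(=O)c2c1` share one core and differ only in the group attached to the thiocarbonyl carbon. The change between them is pyrrolidin-1-yl in place of diisopropylamino on a thiocarbonyl carbon. In a functional assay on MDA-MB-435S cells (Homo sapiens) for antiproliferative activity, read by MTT assay, with a stated time of 72 h (on this read-out lower numbers stand for stronger inhibition and higher numbers for weaker inhibition), compound 1 gives 1800 nM, and in this assay compound 3 gives 1800 nM. The step that this change made is no change at the digits printed from compound 1 to compound 3 (within the scatter).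

Compound 2 `CC(C)N(C(=S)SCc1oc2ccccc2c(=O)c1Cl)C(C)C` carries the diisopropylamino group on a second core; the difference between the two cores is not broken down here. In this assay compound 2 gives 23600 nM, the highest of the three numbers, and its distance to compound 1 and to compound 3 lies beyond the usual scatter of repeated measurements.

Compound 4 `O=c1c(Cl)c(CSC(=S)N2CCCC2)oc2ccccc12` has not been measured. It stands to compound 2 as compound 3 stands to compound 1: the change is pyrrolidin-1-yl in place of diisopropylamino on a thiocarbonyl carbon, on the same place, with the same neighbours, so it is the same change seen once before.

Because the earlier step of no change at the digits printed from compound 1 to compound 3 (within the scatter) left the number where it was, the step from compound 2 to compound 4 in this assay is expected to be a 1.0-fold lower number from compound 2 to compound 4 (0.01 log units; within the scatter). On that basis compound 4 is estimated to give about 23000 nM in this assay, with a likely range from 10000 nM to 50000 nM. This expectation rests on a single earlier pair and on a different core, so it is held loosely.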

Compound 4, half-maximal inhibitory concentration: 1800 nM
Beside the measured number, compound 4's estimate is 13-fold (1.11 log units) above it, and the stated range ends above it.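

On the core of compound 2, putting pyrrolidin-1-yl in place of diisopropylamino gives a 13-fold lower number from compound 2 to compound 4 (1.12 log units; beyond the scatter) in this assay, so here the swap has a large effect. Set beside the earlier pair, the same swap does not carry over from one core to the other with the same size: the same change on two cores in this assay, no change at the digits printed (within the scatter) from compound 1 to compound 3 and a 13-fold lower number (1.12 log units; beyond the scatter) from compound 2 to compound 4, 13-fold (1.12 log units) apart, beyond the scatter of two such steps. This shows that, in these two pairs, what the swap does depends on the core it is made on, so a result from one core is a poor guide to the other; it does not show which feature of the cores is responsible, since the two cores differ in more than one way, and two pairs say nothing about how the swap would behave on any further core.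

As far as these compounds go, it remains open whether other amines on the thiocarbonyl carbon, such as piperidin-1-yl, morpholin-4-yl or dimethylamino, would follow pyrrolidin-1-yl or diisopropylamino on each core. Also open, from the compounds shown here alone, is how the swap would behave on a core that carries only one of the features that separate the two, for example the chloro group without any other difference.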